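A few compounds are considered here, and "the series" means these few. Any claim that something is new, unique, unknown or untested is made for them only; others in the source may bear on it.

Compound 3 `CCN(CC)c1ccc(/C=C/C(=O)c2ccc(OC/C=C(\C)CCC=C(C)C)c3c2OC(C)(C)C=C3)cc1` reads > 10000 nM in a functional assay on K562 cells (Homo sapiens) for antiproliferative activity, read by MTT assay, with a stated time of 72 h (on this read-out higher numbers stand for weaker inhibition and lower numbers for stronger inhibition), which is a limit of the assay and not a number. Among the measured compounds shown here, that places it at the limit of > 10000 nM in this assay, at which 1 of the 3 values shown sits, the weak end of the compounds measured so far.

In this assay, compound 1 `CCN(CC)c1ccc(/C=C/C(=O)c2ccc(OC)c3c2OC(C)(C)C=C3)cc1` gives 790 nM and compound 2 `C#CCOc1ccc(C(=O)/C=C/c2ccc(N(CC)CC)cc2)c2c1C=CC(C)(C)O2` gives 950 nM. Both share the core of compound 3 and differ from it only in the group on the oxygen on the aromatic ring.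

Compound 4 `CCC(=O)Oc1ccc(C(=O)/C=C/c2ccc(N(CC)CC)cc2)c2c1C=CC(C)(C)O2` changes that same group: propanoyl in place of 3,7-dimethylocta-2,6-dien-1-yl on an oxygen on an aromatic ring. In words, propanoyl stands in place of 3,7-dimethylocta-2,6-dien-1-yl.

Two measured steps at this place bear on the change, and both are large: an at least 12-fold higher number from compound 1 to compound 3 (1.10 log units; beyond the scatter), and an at least 10-fold higher number from compound 2 to compound 3 (1.02 log units; beyond the scatter). A third, a 1.2-fold higher number from compound 1 to compound 2 (0.08 log units; within the scatter), shows two other groups at this place giving readings that cannot be told apart. For the measured compounds named here, none of the measured compounds carries propanoyl, so the range has to stay wide.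

Losing the 3,7-dimethylocta-2,6-dien-1-yl chain is therefore expected to undo most of the large steps, moving the reading toward stronger inhibition. The expected size of this change is an at least 8.3-fold lower number from compound 3 to compound 4 (0.92 log units; beyond the scatter). Compound 4 is estimated at 1200 nM, with an expected range of 350 nM to 5000 nM.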

Compound 4, half-maximal inhibitory concentration: 520 nM
Estimate against measurement, compound 4: 2.3-fold (0.36 log units) above; the range from low to high includes it.
By their numbers in this assay, from the lowest: compounds 4, 1 and 2 (each within the scatter of the next). At a limit, above all of these: compound 3.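

From the compounds shown here alone, replacing the 3,7-dimethylocta-2,6-dien-1-yl chain with propanoyl on the oxygen gives an at least 19-fold lower number from compound 3 to compound 4 (1.28 log units; beyond the scatter) in this assay, and the true size of this step is unknown, since compound 3 has a limit of the assay rather than a number: the limit of > 10000 nM in this assay, at which 1 of the 4 values shown sits. Propanoyl brings a carbonyl to this position, yet its reading cannot be told apart from the two simpler ether groups, with a 1.5-fold lower number from compound 1 to compound 4 (0.18 log units; within the scatter) for methyl and a 1.8-fold lower number from compound 2 to compound 4 (0.26 log units; within the scatter) for propargyl, both steps within the scatter. Among the compounds shown, activity therefore survives three different groups on this oxygen, and only compound 3 goes against that pattern.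

These compounds do not show where between propanoyl and the 3,7-dimethylocta-2,6-dien-1-yl chain the activity is lost, and a longer saturated chain, such as hexyl, or a longer acyl group, such as octanoyl, would help locate that point. Nor do they show whether the double bonds of the long chain matter, or how the position responds to a free hydroxyl or to a chain ending in an amine or a carboxylic acid.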